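The source may report more compounds than this note shows. Statements on the series, on what has been measured and on what is new or still open speak of the compounds shown alone.

Measured in a functional assay on A549 cells (Homo sapiens) for antiproliferative activity, read by MTT assay, with a stated time of 72 h; on this read-out higher numbers stand for weaker inhibition and lower numbers for stronger inhibition:
Compound 1 `CCOc1ccc(-c2ncnn2-c2cc(OC)c(OC)c(OC)c2)cc1Cl`: 10 nM
Compound 2 `COc1cc(-n2ncnc2-c2ccc(Cl)c(Cl)c2)cc(OC)c1OC`: > 10000 nM
Compound 3 `COc1cc(-n2ncnc2-c2ccc(OC(C)C)cc2)cc(OC)c1OC`: > 10000 nM

Compound 2 gives no number, only the limit > 10000 nM. Compound 3 also reads as a limit, > 10000 nM. Together these make up (the limit of > 10000 nM in this assay, at which 2 of the 3 values shown sit).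

Compound 4 `COc1cc(-n2ncnc2-c2cccc(F)c2)cc(OC)c1OC` differs from compound 2 as follows: 3-fluorophenyl in place of 3,4-dichlorophenyl on an aromatic carbon. Among the compounds with values here, the one measured step, an at least 1000-fold higher number from compound 1 to compound 2 (3.00 log units; beyond the scatter), was large and beyond the scatter, and it bears on this change only indirectly. Compound 4 lacks the ethoxy group that this step removed, so no recovery of that size is expected. The expected change, none beyond the scatter, is a number no higher from compound 2 to compound 4 (the limit leaves the size open). For compound 4 the estimated value is 10000 nM, with an expected range of 2000 nM to 30000 nM.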

Compound 4, half-maximal inhibitory concentration: > 10000 nM
Compound 4: only a limit was reported (the forecaster's own chance of this, stated with the estimate: 70%); the middle value sits exactly at the limit.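

Within the data shown here, compound 2 and compound 4 each give only a limit, so no step between them can be read: the limit of > 10000 nM in this assay, at which 3 of the 4 values shown sit. The compounds shown leave open whether 3-fluorophenyl and 3,4-dichlorophenyl differ at all in this assay.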